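Swapping chloro for fluoro on the fused ring

A few compounds are considered here, and "the series" means these few. Any claim that something is new, unique, unknown or untested is made for them only; others in the source may bear on it.

Compound 1 `COc1ccc(S(=O)(=O)c2cnc3ccc(Cl)cc3c2N2CCC(C)CC2)cc1Cl` gives 46%.
Compound 2 `CC1CCN(c2c(S(=O)(=O)c3cc(F)cc(F)c3)cnc3ccc(Cl)cc23)CC1` gives 93%.

Of the compounds shown here, two have so far been measured in an assay on isolated protein for displacement of a labelled ligand from metabotropic glutamate receptor 5 (Homo sapiens), with a stated time of 60 min, tested at 1 uM; on this read-out higher numbers stand for more inhibition at the one concentration tested (going by the name of the read-out) and lower numbers for less inhibition. Compound 1 stands lowest of the two numbers with 46%, while compound 2 reaches 93%. Within the data shown here, the one step between them, a number 47 percentage points higher from compound 1 to compound 2 (beyond the scatter), lies beyond the scatter, but it concerns the aryl group on the sulfonyl sulfur, not the fused ring.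

Compound 3 `COc1ccc(S(=O)(=O)c2cnc3ccc(F)cc3c2N2CCC(C)CC2)cc1Cl` differs from compound 1 at a different place: fluoro in place of chloro on an aromatic carbon. Among the measured compounds shown here, no measured step touches this aromatic carbon, so the large step between compound 1 and compound 2 does not bear on the change, and nothing in the data points either way. The expectation is therefore for no step beyond the scatter, no change at the digits printed from compound 1 to compound 3 (within the scatter). Compound 3 is estimated at 46%, with a range from 28% to 64%.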

Compound 3, a percentage reported as inhibition, at one concentration (the size of the read-out at that concentration, not a potency): 82%
Compound 3: middle estimate off by 36 percentage points, on the low side, outside the stated range (above it).
By their numbers in this assay, from the lowest: compound 1; then compound 3; then compound 2.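

In this assay, fluoro in place of chloro on this aromatic carbon gives a number 36 percentage points higher from compound 1 to compound 3 (beyond the scatter), with the 3-chloro-4-methoxyphenyl on the sulfonyl sulfur left unchanged. The earlier compounds shown here showed a large step only at the sulfonyl aryl group, whereas this result shows that the read-out also responds to a single halogen exchange on the fused ring, so two separate places on the shared core now each carry a step beyond the scatter. Nothing measured here explains why the fluoro compound reads higher.

The compounds shown leave open whether fluoro at this carbon would bring a similar step alongside the 3,5-difluorophenyl group of compound 2. They also leave open how a methyl, a methoxy or a nitrile at this carbon would read.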